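The source may report more compounds than this note shows. Statements on the series, on what has been measured and on what is new or still open speak of the compounds shown alone.

Measured so far:
- compound 1, `CSc1coc(C(=O)CCCCCCc2ccccc2)n1` — in an assay on isolated protein for inhibition of Fatty-acid amide hydrolase 1 (Rattus norvegicus) (a lower number here means a stronger inhibitor, a higher number a weaker inhibitor), compound 1 gives 29 nM
- compound 2, `O=C(CCCCCCc1ccccc1)c1nc(-c2ccccc2)co1` — in this assay compound 2 gives 65 nM

Both compounds share a core that carries a long ketone-linked chain ending in a phenyl group; they differ only in the small group on one aromatic carbon of the five-membered ring. Compound 2, which carries a phenyl there, stands at the higher of the two numbers, and the step that separates it from compound 1 is a 2.2-fold higher number from compound 1 to compound 2 (0.35 log units; beyond the scatter), a modest one.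

Compound 3, `CN(C)C(=O)c1coc(C(=O)CCCCCCc2ccccc2)n1`, keeps everything else and changes that same aromatic carbon once more: dimethylcarbamoyl in place of phenyl on an aromatic carbon. For the measured compounds named here, the only measured step that bears on this position is the one from compound 1 to compound 2, and it shows that swapping groups here moves the number only modestly. As far as these compounds go, nothing measured involves a dimethylcarbamoyl group, so the direction of the new step is unknown. A step of modest size, in either direction, or none beyond the scatter, is therefore expected, written as a 1.1-fold lower number from compound 2 to compound 3 (0.03 log units; within the scatter). Compound 3 is estimated at 60 nM, within a range from 15 nM to 250 nM.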

Compound 3, inhibition constant: 35 nM
For compound 3 the middle estimate is 1.7-fold (0.23 log units) above the measured one; the range from low to high includes it.
By their numbers in this assay, from the lowest: compounds 1, 3 and 2 (each within the scatter of the next, the first and the last beyond it).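

In this assay, putting dimethylcarbamoyl on this aromatic carbon gives a 1.9-fold lower number from compound 2 to compound 3 (0.27 log units; within the scatter) and also a 1.2-fold higher number from compound 1 to compound 3 (0.08 log units; within the scatter) so compound 3 cannot be told apart from either neighbour, even though compound 1 and compound 2 do stand apart from each other. This position, next to the ring nitrogen, has now carried methylsulfanyl, phenyl and dimethylcarbamoyl, and the new group brings a hydrogen-bond acceptor and no ring, yet all three numbers stay close together, so a ring on this carbon is not needed to keep the number where it is in these compounds. No measurement shown here explains why such different groups give such similar numbers.

The compounds shown leave open whether a free amine or a carboxylic acid on this same carbon would stay as close to these numbers as the three groups so far. They also leave open whether the same pattern would hold with a shorter chain in place of the long chain that ends in a phenyl group.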